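The compounds below may be only part of what the source reports. "The series", "measured", "known", "first", "only" and "open" are said of these compounds alone.

Working notes on the series. Three compounds sharing the core of compound 1 `COc1ccc(C(=O)N2CCN(Cc3nc4ccccc4n3Cc3cccc(C)c3)CC2)cc1` have been run in an assay on isolated protein for inhibition of aldehyde dehydrogenase 1A1 (Homo sapiens), read by spectrophotometry, tested at 10 uM; a lower number here means less inhibition, a higher number more inhibition at the concentration tested (going by the name of the read-out). Compound 1 gives 55.5%. Compound 2 `Cc1cccc(Cn2c(OC3CCN(C(=O)c4ccco4)CC3)nc3ccccc32)c1` gives 68.3%. Compound 3 `Cc1cccc(Cn2c(CN3CCN(C(=O)c4ccc(C(C)C)cc4)CC3)nc3ccccc32)c1` gives 67.6%, which places it second highest of the three: its value and that of compound 2 lie within the scatter of each other, while compound 1 sits beyond the scatter below it. Among the compounds with values here, the one step measured so far, a number 12.1 percentage points higher from compound 1 to compound 3 (beyond the scatter), is the only change at the aromatic ring on the carbonyl carbon.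

Compound 4 `Cc1cccc(Cn2c(CN3CCN(C(=O)C4CCCC4)CC3)nc3ccccc32)c1` is the next member. The change from compound 3 is cyclopentyl in place of 4-isopropylphenyl on a carbonyl carbon. Within the data shown here, no measured step removes the aromatic ring at this position outright; the change from compound 1 to compound 3 only swaps a substituent on that ring, so it bears on compound 4 at most indirectly. Compound 2, which carries a different carbonyl group, gives a value within the scatter of compound 3. In this assay compound 4 is therefore expected to come out somewhat lower than compound 3, by about a number 12.6 percentage points lower from compound 3 to compound 4 (beyond the scatter), though a result within the scatter would not surprise. The estimate for compound 4 is 55%, with a range from 35% to 72%.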

Compound 4, a percentage reported as inhibition, at one concentration (the size of the read-out at that concentration, not a potency): 67.5%
Beside the measured number, compound 4's estimate is 12.5 percentage points below it, within the range that was stated.
By their numbers in this assay, from the lowest: compound 1; then compounds 4, 3 and 2 (each within the scatter of the next).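

In this assay cyclopentyl in place of 4-isopropylphenyl on a carbonyl carbon gives a number 0.1 percentage points lower from compound 3 to compound 4 (within the scatter) and so the aromatic ring at this place is not needed to hold the read-out at the level of compound 3. Cyclopentyl in place of 4-methoxyphenyl gives a number 12 percentage points higher from compound 1 to compound 4 (beyond the scatter) and so the earlier step at this place does not depend on isopropyl in particular, since a non-aromatic ring with no isopropyl also stands beyond the scatter above compound 1. Nothing at hand accounts for either step.

Going by these compounds, whether the read-out holds with a smaller group such as methyl, an open alkyl chain, an amine or a carboxylic acid on this carbonyl carbon remains open. Readings at a single concentration also leave open whether compound 3 and compound 4 match in potency.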